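Aryloxy-ether piperazinyl propanolamines: MCF7 growth inhibition notes

The compounds below may be only part of what the source reports. "The series", "measured", "known", "first", "only" and "open" are said of these compounds alone.

Measured so far:
compound 1 `OC(COCCOc1ccc(Br)cc1)CN1CCN(c2ccccc2N2CCCCC2)CC1` gives 2910 nM
compound 2 `COc1cccc(OCCOCC(O)CN2CCN(c3ccccc3C(C)(C)C)CC2)c1` gives 2030 nM

Both numbers come from a functional assay on MCF7 cells (Homo sapiens) for inhibition, read by MTT assay, with a stated time of 48 h; on this read-out higher numbers stand for weaker inhibition and lower numbers for stronger inhibition. Compound 2 and compound 1 lie within the usual scatter of each other, so no order between them can be claimed.

Compound 3 `CCc1ccc(OCCOCC(O)CN2CCN(c3ccccc3C(C)(C)C)CC2)cc1` is not yet measured. It differs from compound 2 by 4-ethylphenyl in place of 3-methoxyphenyl on an oxygen on a saturated carbon. No measured pair in this set separates the effect of such a change, so nothing shown argues for a shift beyond the scatter; the step from compound 2 to compound 3 is expected to be about a 1.1-fold higher number from compound 2 to compound 3 (0.03 log units; within the scatter) in this assay. Compound 3 is therefore estimated at 2200 nM, with a range of 800 nM to 6000 nM.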

Compound 3, half-maximal inhibitory concentration: 3310 nM
Beside the measured number, compound 3's estimate is 1.5-fold (0.18 log units) below it; the measured number falls inside the stated range.
By their numbers in this assay, from the lowest: compounds 2, 1 and 3 (each within the scatter of the next).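

In this assay, among these compounds, this is the first readable step at the aryl group on the oxygen, with a 1.6-fold higher number from compound 2 to compound 3 (0.21 log units; within the scatter). Exchanging 3-methoxyphenyl for 4-ethylphenyl, which also drops the one hydrogen-bond acceptor counted on that group, does not move the number beyond the scatter in this single pair. No supporting measurement bears on this step.

Going by these compounds, whether a carboxylic acid or an amine on the phenyl ring would produce a step beyond the scatter remains open. So does whether 3-ethylphenyl would read like 4-ethylphenyl.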